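Changing the halogenated phenyl group: an estimate for compound 3

A few compounds are considered here, and "the series" means these few. Any claim that something is new, unique, unknown or untested is made for them only; others in the source may bear on it.

Compound 1 `O=C(Nc1ccc(Oc2ccnc3[nH]ccc23)cc1)c1nn(-c2ccc(Cl)cc2)ccc1=O`: 32400 nM
Compound 2 `O=C(Nc1ccc(Oc2ccnc3[nH]ccc23)cc1)c1nn(-c2ccc(Br)cc2F)ccc1=O`: 12800 nM
Compound 3 `O=C(Nc1ccc(Oc2ccnc3[nH]ccc23)cc1)c1nn(-c2ccc(Cl)c(F)c2)ccc1=O`: not yet measured

In a functional assay on PC-3 cells (Homo sapiens) for cytotoxicity, read by MTT assay, with a stated time of 72 h (on this read-out lower numbers stand for stronger inhibition and higher numbers for weaker inhibition), compound 1 gives 32400 nM and compound 2 gives 12800 nM. Among the compounds with values here, compound 2 thus shows the lower of the two numbers measured so far, with compound 1 as its only neighbour. The step to compound 3 is 4-chloro-3-fluorophenyl in place of 4-bromo-2-fluorophenyl on an aromatic nitrogen. Within the data shown here, only one measured step touches this place: a 2.5-fold lower number from compound 1 to compound 2 (0.40 log units; beyond the scatter), which exchanged the 4-chlorophenyl group for the 4-bromo-2-fluorophenyl group. Compound 3 keeps the chlorine of compound 1 while adding a fluorine, and a modest move back toward the number of compound 1 32400 nM is expected, so the expected change is a 1.6-fold higher number from compound 2 to compound 3 (0.19 log units; within the scatter). Compound 3 is therefore estimated at 20000 nM, with a range from 8000 nM to 50000 nM.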

Compound 3, half-maximal inhibitory concentration: 7780 nM
Compound 3: the middle estimate sits 2.6-fold (0.41 log units) above what was measured; measured number outside the range, below it.
By their numbers in this assay, from the lowest: compounds 3 and 2 (each within the scatter of the next); then compound 1.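

Adding one fluorine to the 4-chlorophenyl group of compound 1 is the first single-atom change at this position, and in this assay it gives a 4.2-fold lower number from compound 1 to compound 3 (0.62 log units; beyond the scatter). This shows that the phenyl group on the aromatic nitrogen can respond to one added fluorine, a point the earlier step could not isolate because it changed the halogens in more than one way. The exchange of 4-bromo-2-fluorophenyl for 4-chloro-3-fluorophenyl gives a 1.6-fold lower number from compound 2 to compound 3 (0.22 log units; within the scatter), so these two halogen patterns cannot be told apart here, and no accompanying measurement explains the fluorine step.

The compounds shown carry only halogens on this phenyl group, so it remains open how a methoxy group, a nitrile or an amine would fare there. Also open, going by these compounds, is whether a fluorine without the chlorine would give a similar number.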